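The source may report more compounds than this note shows. Statements on the series, on what has been measured and on what is new or still open speak of the compounds shown alone.

Working notes on the series. Three compounds sharing one core, differing only in the group on an oxygen on an aromatic ring, have been read in a functional assay on A-375 cells (Homo sapiens) for cytotoxicity, read by MTT assay; on this read-out higher numbers stand for weaker inhibition and lower numbers for stronger inhibition. Compound 1 `COc1ccc(/C=C/C(=O)c2ccc(OC)c3c2OC(C)(C)C=C3)cc1OCCO`, with 2-hydroxyethyl, gives 9600 nM. Compound 2 `COc1ccc(/C=C/C(=O)c2ccc(OC)c3c2OC(C)(C)C=C3)cc1OC(=O)C(C)C`, with isopropylcarbonyl, gives 310 nM. Compound 3 `COc1ccc(/C=C/C(=O)c2ccc(OC)c3c2OC(C)(C)C=C3)cc1OC(=O)C1CC1`, with cyclopropylcarbonyl, gives 380 nM. Compound 3 cannot be told apart from compound 2, with a 1.2-fold higher number from compound 2 to compound 3 (0.09 log units; within the scatter). Against the hydroxyethyl compound the gap is wide, with a 25-fold lower number from compound 1 to compound 3 (1.40 log units; beyond the scatter), much like a 31-fold lower number from compound 1 to compound 2 (1.49 log units; beyond the scatter).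

Next is compound 4 `COc1ccc(/C=C/C(=O)c2ccc(OC)c3c2OC(C)(C)C=C3)cc1OS(=O)(=O)Cc1ccccc1`, where benzylsulfonyl takes the place of cyclopropylcarbonyl: benzylsulfonyl in place of cyclopropylcarbonyl on an oxygen on an aromatic ring. Among the compounds with values here, no measured step covers a sulfonyl group, so the evidence is indirect. The swap between the two carbonyl groups, a 1.2-fold higher number from compound 2 to compound 3 (0.09 log units; within the scatter), says little about a change of this kind. The large steps from compound 1 show that this oxygen substituent can move the number strongly, so a flat result cannot be assumed. A moderate move towards a higher number is expected, short of the full gap to compound 1, and with low confidence. The expected step is a 2.4-fold higher number from compound 3 to compound 4 (0.37 log units; beyond the scatter). Compound 4 is estimated at 900 nM, within an estimated range of 200 nM to 4000 nM.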

Compound 4, half-maximal inhibitory concentration: > 10000 nM
Compound 4: only a limit was reported; the forecaster's own chance of this, stated with the estimate: 5%; middle value at least 11-fold (1.04 log units) from the limit.
By their numbers in this assay, from the lowest: compounds 2 and 3 (each within the scatter of the next); then compound 1. At a limit, above all of these: compound 4.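

The reading for compound 4 in this assay is a limit of the assay and not a number: the limit of > 10000 nM in this assay, at which 1 of the 4 values shown sits.

Putting benzylsulfonyl in place of either carbonyl group on this oxygen gives a large step, with an at least 26-fold higher number from compound 3 to compound 4 (1.42 log units; beyond the scatter) and an at least 32-fold higher number from compound 2 to compound 4 (1.50 log units; beyond the scatter), so the flat swap between isopropylcarbonyl and cyclopropylcarbonyl does not carry over to this sulfonyl group. Compound 1 and compound 4 cannot be put in order, with an at least 1.0-fold higher number from compound 1 to compound 4 (0.01 log units; that floor lies within the scatter), and among the four compounds only the two carbonyl compounds, compound 2 and compound 3, read low, while 2-hydroxyethyl in compound 1 and benzylsulfonyl in compound 4 both go with high numbers.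

Benzylsulfonyl differs from the carbonyl groups in both its sulfonyl link and its benzyl part, so the compounds shown do not separate the two; a methylsulfonyl group and a phenylacetyl group on this oxygen would pull them apart. Also open, from the compounds shown here alone, is whether a plain acetyl group or a longer acyl chain here stays with compound 2 and compound 3.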